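Mast cell inhibition: replacing 3-chlorophenyl with 4-hydroxyphenyl

The source may hold more compounds than are shown below. What is called first, only, known or untested is meant among the compounds shown, and "the series" means these compounds.

Compound 1 `CCOC(=O)c1cnc2n(c1=O)C(C)CC/C2=N\Nc1ccc(C(=O)O)cc1`: 66000 nM
Compound 2 `CC1CCC(=NNc2ccccc2)c2ncc(C(=O)O)c(=O)n21`: 2200 nM
Compound 3 `CC1CC/C(=N\Nc2cccc(Cl)c2)c2ncc(C(=O)O)c(=O)n21`: 311000 nM

These three compounds were tested in a functional assay (mast cells) for inhibition, with Rattus norvegicus as the target; a lower number here means that less compound is needed, a higher number that more compound is needed for the effect. Among them, compound 3 has the highest number, at 311000 nM, so it needs the most compound for the effect. Its distance to each of the other two lies beyond the usual scatter of repeated measurements.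

The next compound, compound 4 `CC1CC/C(=N\Nc2ccc(O)cc2)c2ncc(C(=O)O)c(=O)n21`, carries 4-hydroxyphenyl in place of 3-chlorophenyl on an amine nitrogen. None of the three measured compounds carries 4-hydroxyphenyl, so the data give no direct guide to this change. Still, compound 3 is the high end of a wide spread, with compound 1 at 66000 nM and compound 2 at 2200 nM, and a new compound is more likely to fall inside that spread than above it. The expected change is a 16-fold lower number from compound 3 to compound 4 (1.19 log units; beyond the scatter), towards a lower number and beyond the scatter. For compound 4 the estimate is 20000 nM, with an expected range from 2500 nM to 150000 nM.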

Compound 4, half-maximal effective concentration: 1300 nM
Beside the measured number, compound 4's estimate is 15-fold (1.19 log units) above it; the whole stated range lies above it.
By their numbers in this assay, from the lowest: compounds 4 and 2 (each within the scatter of the next); then compound 1; then compound 3.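

In this assay the group on this amine nitrogen turns out to matter greatly: 4-hydroxyphenyl in place of 3-chlorophenyl gives a 240-fold lower number from compound 3 to compound 4 (2.38 log units; beyond the scatter) even though both groups have the same count of heavy atoms and one six-membered aromatic ring of carbon only. The change takes the series from its highest number to its lowest, where compound 4 at 1300 nM and compound 2 at 2200 nM lie within the usual scatter of each other. Nothing at hand explains why the step is so large.

Because the swap changes both the substituent and its place on the ring, these compounds cannot separate those two changes. A 4-chlorophenyl or 3-hydroxyphenyl group would tell them apart, and a 4-methoxyphenyl group would test whether the hydroxyl hydrogen counts.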